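Benzyl triazole chalcone series: working notes on compound 3

This account rests on a few compounds, and the source may have more. Where it says the series, first, only, none or still open, it means among the compounds named here.

Measured so far:
- compound 1, `O=C(/C=C/c1ccc(OCc2cn(Cc3cccc(Br)c3)nn2)cc1)c1ccc(Br)cc1`, in a functional assay on A549 cells (Homo sapiens) for inhibition, read by MTT assay, with a stated time of 48 h, tested at 10 uM (a lower number here means less inhibition of growth, a higher number more inhibition of growth at the concentration tested), compound 1 gives 44%
- compound 2, `O=C(/C=C/c1ccc(OCc2cn(Cc3ccc(Br)cc3)nn2)cc1)c1ccc(Br)cc1`, in this assay compound 2 gives 27%

Compound 2 stands lowest of the two numbers; its nearest neighbour is compound 1, and the step of a number 17 percentage points lower from compound 1 to compound 2 (beyond the scatter) lies beyond the scatter. Compound 3, `O=C(/C=C/c1ccc(OCc2cn(Cc3ccccc3F)nn2)cc1)c1ccc(Br)cc1`, differs from compound 2 by 2-fluorophenyl in place of 4-bromophenyl on a saturated chain carbon bound to an aromatic nitrogen. Within the data shown here, no measured step covers this change: the only step in hand, a number 17 percentage points lower from compound 1 to compound 2 (beyond the scatter), moves a bromine on the same ring from one position to another and keeps the halogen, whereas here the halogen itself and its position change together. That step shows the benzyl ring can shift the number beyond the scatter, but its direction for a 2-fluorophenyl is not settled by these data. Compound 3 is therefore expected near the middle of the two measured numbers, a step of a number 8 percentage points higher from compound 2 to compound 3 (within the scatter) from compound 2, and its value in this assay is estimated at 35% (range 15% to 55%).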

Compound 3, percent growth inhibition at one concentration: 38%
Estimate against measurement, compound 3: 3 percentage points below, within the range that was stated.
By their numbers in this assay, from the lowest: compound 2; then compounds 3 and 1 (each within the scatter of the next).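

In this assay, the change from 4-bromobenzyl to 2-fluorobenzyl gives a number 11 percentage points higher from compound 2 to compound 3 (beyond the scatter) and so shows that a swap of halogen and its place on this ring can also move the number beyond the scatter. Against 3-bromophenyl, the same 2-fluorophenyl gives a number 6 percentage points lower from compound 1 to compound 3 (within the scatter) and leaves these two unordered, so among the three compounds only the 4-bromophenyl of compound 2 stands apart, and bromine versus fluorine alone does not sort the numbers. Nothing in hand gives a reason for these differences.

Halogen and place change together in the step to compound 3, so their shares in it remain unseparated. Also open, going by these compounds, is how this position responds to a group other than a halogen, such as an amine or a carboxylic acid on the ring, or to a longer chain in place of the single saturated carbon.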